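The source may report more compounds than this note shows. Statements on the series, on what has been measured and on what is new or still open speak of the compounds shown alone.

Values in a functional assay on PC-12 cells (Rattus norvegicus) for cytotoxicity, read by MTT assay, with stated times of 3 h and 2 h, tested at 0.1 uM; a higher number here means a stronger effect of the compound at the concentration tested, a lower number a weaker effect:

Compound 1 `O=C(CCCCC1CCSS1)NCc1cn(CCCCOc2ccc3cc(-c4ccccc4)c(=O)oc3c2)nn1`: 38.6%
Compound 2 `O=C(CCCCC1CCSS1)NCc1cn(CCCCOc2ccc3cc(-c4ccc(Br)cc4)c(=O)oc3c2)nn1`: 34.2%
Compound 3 `O=C(CCCCC1CCSS1)NCc1cn(CCCCOc2ccc3cc(-c4ccc(Cl)cc4)c(=O)oc3c2)nn1`: 38.8%

Compound 3 holds the highest of the three numbers, yet its neighbours lie close: a number 0.2 percentage points higher from compound 1 to compound 3 (within the scatter) and a number 4.6 percentage points higher from compound 2 to compound 3 (within the scatter), so no order among the three can be read. Compound 4 `O=C(CCCCC1CCSS1)NCc1cn(CCCCOc2ccc3cc(-c4ccc(Cl)c(Cl)c4)c(=O)oc3c2)nn1` differs from compound 3 by chloro in place of hydrogen on an aromatic carbon. Among the compounds with values here, the steps that bear on it are the earlier halogen-for-hydrogen exchanges on the same ring, a number 0.2 percentage points higher from compound 1 to compound 3 (within the scatter) and a number 4.4 percentage points lower from compound 1 to compound 2 (within the scatter), neither of which moved this assay beyond the scatter. A further chloro is therefore expected to leave the read-out roughly where compound 3 stands, with a number 0.8 percentage points lower from compound 3 to compound 4 (within the scatter) as the expected step. Compound 4 is estimated at 38%, within 29% to 47%.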

Compound 4, a percentage reported as activity, at one concentration (the size of the read-out at that concentration, not a potency): 39.6%
The estimate for compound 4 lay 1.6 percentage points below the measured number, within the range that was stated.
By their numbers in this assay, from the lowest: compounds 2, 1, 3 and 4 (each within the scatter of the next).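

In this assay, a number 0.8 percentage points higher from compound 3 to compound 4 (within the scatter) shows that a second chloro, ortho to the first, leaves the read-out unmoved at this position, extending the earlier single-halogen picture to a 3,4-dichlorophenyl group. Against the other two compounds, a number 1 percentage points higher from compound 1 to compound 4 (within the scatter) and a number 5.4 percentage points higher from compound 2 to compound 4 (within the scatter) also leave the 3,4-dichlorophenyl compound indistinguishable, so the aromatic ring tolerates this added substitution without a readable change in this assay. No available evidence bears on this result. Going by these compounds, whether an amine or a carboxylic acid on this ring would move the read-out beyond the scatter remains open.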